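The source may hold more compounds than are shown below. What is called first, only, known or untested is meant among the compounds shown, and "the series" means these compounds.

Working notes on the series. Compound 1 `COc1cc(N(C)C(=O)c2cccc(F)c2)cc(OC)c1OC`, compound 2 `COc1cc(N(C)C(=O)c2ccccc2)cc(OC)c1OC` and compound 3 `COc1cc(N(C)C(=O)c2ccc(F)cc2)cc(OC)c1OC` share one core and differ only in the aroyl ring. In a functional assay on Daoy cells (Homo sapiens) for cytotoxicity, read by MTT assay, with a stated time of 72 h (a higher number here means a weaker inhibitor, a lower number a stronger inhibitor), compound 1 gives only the assay limit >= 125000 nM. Compound 2 likewise gives only the limit >= 125000 nM. Compound 3 stands at the limit >= 125000 nM, so its place among the numbers is known only as a limit, namely (the limit of >= 125000 nM in this assay, at which 3 of the 3 values shown sit). The steps a step that the two limits leave unreadable from compound 1 to compound 2, a step that the two limits leave unreadable from compound 1 to compound 3 and a step that the two limits leave unreadable from compound 2 to compound 3 are accordingly all unreadable. Compound 4 `COc1cc(N(C)C(=O)c2ccc([N+](=O)[O-])cc2)cc(OC)c1OC` differs from compound 3 by nitro in place of fluoro on an aromatic carbon. Among the compounds with values here, no measured step gives a readable size, so no step beyond the scatter in this assay can be foreseen in either direction. Compound 4 is expected to give 125000 nM, within 30000 nM to 250000 nM, most probably again only a limit. The estimate implies a step of a number no higher from compound 3 to compound 4 (the limit leaves the size open), which is expected to lie within the scatter.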

Compound 4, half-maximal inhibitory concentration: >= 125000 nM
Compound 4 was reported as a limit; the forecaster's own chance of this, stated with the estimate: 80%; the middle value lies on the limit itself.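

In this assay the steps to compound 4 from compound 2 and compound 3 cannot be read, as all the compounds shown share one limit: the limit of >= 125000 nM in this assay, at which 4 of the 4 values shown sit. The compounds shown leave open whether any change on the aroyl ring gives a readable number.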